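Swapping the amine on the cyclohexenyl of compound 1

The source may report more compounds than this note shows. Statements on the series, on what has been measured and on what is new or still open speak of the compounds shown alone.

Measured so far:
compound 1, `N#Cc1ccc2[nH]cc(C3=CCC(NCc4ccccc4)CC3)c2c1`, 27%
compound 2, `Fc1ccc2[nH]cc([C@H]3CC[C@@H](NCc4ccccc4)CC3)c2c1`, 9%

In an assay on cell membranes for binding affinity to Adrenergic receptor alpha-1 (Rattus norvegicus), tested at 1 uM (on this read-out higher numbers stand for more inhibition at the one concentration tested (going by the name of the read-out) and lower numbers for less inhibition), compound 1 gives 27%, the higher of the two numbers measured; compound 2 with 9% sits below it by a gap that exceeds the usual scatter. Within the data shown here, no single-point step between the two measured compounds can be drawn, since they differ in more than one place.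

Compound 3, `N#Cc1ccc2[nH]cc(C3=CCC(N4CCCCC4)CC3)c2c1`, has not been measured. It differs from compound 1 in one place: piperidin-1-yl in place of benzylamino on a saturated ring carbon. The shared core and the ring that bears the amine stay the same.

Both measured numbers are low, and nothing among them points to a large move in either direction. Compound 3 is therefore expected to give 17%, within a range from 2% to 35%. The step expected in this assay is a number 10 percentage points lower from compound 1 to compound 3 (within the scatter), a small decrease that may well lie within the scatter.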

Compound 3, a percentage reported as inhibition, at one concentration (the size of the read-out at that concentration, not a potency): 10%
Beside the measured number, compound 3's estimate is 7 percentage points above it; the measured number falls inside the stated range.
By their numbers in this assay, from the lowest: compounds 2 and 3 (each within the scatter of the next); then compound 1.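

In this assay, among these compounds, the swap of benzylamino for piperidin-1-yl on a saturated ring carbon gives the first step that can be read at a single place, a number 17 percentage points lower from compound 1 to compound 3 (beyond the scatter), and it shows that the number at this position changes with the amine it carries. The swap removes the aromatic ring and the hydrogen-bond donor together, and this one pair cannot tell which of the two matters. Nothing measured here accounts for the step.

The compounds shown leave open whether phenethylamino, with a longer chain to its aromatic ring, or methylamino, with no such ring, would stand nearer to compound 1 or to compound 3. They also leave open how morpholin-4-yl or dimethylamino would compare with piperidin-1-yl at this position.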